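Benzyl for (ethoxycarbonyl)methyl on the ring nitrogen

The source may report more compounds than this note shows. Statements on the series, on what has been measured and on what is new or still open speak of the compounds shown alone.

Compound 1 `C=CCn1nc(C)c2c(C)nc(CCC)n2c1=O` in a functional assay for inhibition, with Homo sapiens as the target; a higher number here means a weaker inhibitor, a lower number a stronger inhibitor: compound 1 gives 69000 nM; > 48000 nM (2 entries).
Compound 2 `CCCc1nc(C)c2c(C)nn(CC(=O)OCC)c(=O)n12` in this assay: compound 2 gives > 48000 nM, which is a limit of the assay and not a number.

Compound 2 therefore stands only at the edge of what this assay reports, with no single number; a further entry for it also carries no number. Compound 1 the several entries of compound 1 in this assay, 69000 nM; > 48000 nM (2 entries) sits in the same weak region, one value a number and the others at the limit (the limit of > 48000 nM in this assay, at which 1 of the 2 values shown sits). Going by the values given here, no step between measured compounds can be drawn here.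

Compound 3 `CCCc1nc(C)c2c(C)nn(Cc3ccccc3)c(=O)n12` differs from compound 2 by phenyl in place of ethoxycarbonyl on a saturated chain carbon bound to an aromatic nitrogen. With both measured compounds at or near the limit, the expectation for compound 3 is a step of an at least 1.3-fold lower number from compound 2 to compound 3 (0.13 log units; that floor lies within the scatter), that is, no change beyond the scatter in either direction. Compound 3 is estimated at 35000 nM, with a range from 8000 nM to 120000 nM, and a fair chance that only a limit is reported.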

Compound 3, half-maximal inhibitory concentration: > 48000 nM
Compound 3 ended at the assay's limit (the forecaster's own chance of this, stated with the estimate: 50%); at least 1.3-fold (0.13 log units) between middle value and limit.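

In this assay compound 3 gives > 48000 nM, a limit of the assay and not a number. Compound 2 gives > 48000 nM, also a limit, so no step can be read between compound 2 and compound 3. The compounds shown leave open whether benzyl and (ethoxycarbonyl)methyl differ at all in this assay.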